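Hetaryl replacement on the chloroaryl amide core

A few compounds are considered here, and "the series" means these few. Any claim that something is new, unique, unknown or untested is made for them only; others in the source may bear on it.

Measured compounds:
compound 1 `Cc1nc(C(F)(F)F)ccc1C(=O)Nc1ccc(Cl)c(-c2nc3ccccc3[nH]2)c1` gives 12 nM
compound 2 `Cc1nc(C(F)(F)F)ccc1C(=O)Nc1ccc(Cl)c(-n2cc3ccccc3n2)c1` gives 80 nM
compound 3 `Cc1nc(C(F)(F)F)ccc1C(=O)Nc1ccc(Cl)c(-c2ccn(C)n2)c1` gives 550 nM

In an assay on C3H 10T1/2 cells for inhibition of Sonic hedgehog protein (Mus musculus), read by a luciferase reporter (on this read-out lower numbers stand for stronger inhibition and higher numbers for weaker inhibition), compound 1 holds the lowest number of the three, with compound 2 the nearest and compound 3 the furthest. Compound 4 `Cc1nc(C(F)(F)F)ccc1C(=O)Nc1ccc(Cl)c(-c2ncccn2)c1` is not yet measured. It differs from compound 1 in one place: pyrimidin-2-yl in place of 1H-benzimidazol-2-yl on an aromatic carbon.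

Among the compounds with values here, two measured steps bear on this change, both leaving the same group from the same place. The step of a 6.7-fold higher number from compound 1 to compound 2 (0.82 log units; beyond the scatter) replaces it by a fused ring without a hydrogen-bond donor; the step of a 46-fold higher number from compound 1 to compound 3 (1.66 log units; beyond the scatter) replaces it by a small single ring without a donor. The incoming pyrimidin-2-yl shares with both the loss of the donor and with the latter its single-ring size. A step up in the read-out beyond the scatter is therefore expected in this assay, most likely nearer the larger of the two.

For compound 4 the expected step is a 25-fold higher number from compound 1 to compound 4 (1.40 log units; beyond the scatter), giving an estimate of 300 nM, with a range from 80 nM to 1200 nM.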

Compound 4, half-maximal inhibitory concentration: 8000 nM
Compound 4: middle estimate off by 27-fold (1.43 log units), on the low side, and the stated range ends below it.
By their numbers in this assay, from the lowest: compound 1; then compound 2; then compound 3; then compound 4.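

In this assay, within the data shown here, the pyrimidin-2-yl group gives the largest step, a 670-fold higher number from compound 1 to compound 4 (2.82 log units; beyond the scatter), so this position on the aromatic carbon tolerates far less than the earlier compounds indicated. Removing the hydrogen-bond donor does not set a single level, since the groups without a donor still spread widely, with a 100-fold higher number from compound 2 to compound 4 (2.00 log units; beyond the scatter) for the fused ring. Single-ring size does not set the level either, since the two single rings are separated by a 15-fold higher number from compound 3 to compound 4 (1.16 log units; beyond the scatter) and the identity of the ring matters as well as its size.

On these data alone, whether a phenyl or pyridin-2-yl ring at this position would fall as far as pyrimidin-2-yl remains open. Nothing available here accounts for the size of these steps.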